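Branched chain isomers on the shared core

The source may hold more compounds than are shown below. What is called first, only, known or untested is meant among the compounds shown, and "the series" means these compounds.

Values so far in a functional assay on PC-3 cells (Homo sapiens) for cytotoxicity, read by WST assay, with a stated time of 3 days; a lower number here means a stronger inhibitor, a higher number a weaker inhibitor
compound 1 `CCCCn1ccnc1/C=C/C(=O)/C=C/c1coc2ccccc2c1=O` gives 2000 nM
compound 2 `CCCCCn1ccnc1/C=C/C(=O)/C=C/c1coc2ccccc2c1=O` gives 2100 nM
compound 3 `CCCC(C)n1ccnc1/C=C/C(=O)/C=C/c1coc2ccccc2c1=O` gives 3200 nM

Of the three, compound 3 at 3200 nM lies within the scatter of both others, so no order among them can be claimed. The open case is compound 4 `CCC(CC)n1ccnc1/C=C/C(=O)/C=C/c1coc2ccccc2c1=O`, which has the same atoms as compound 3 joined differently. The change is pentan-3-yl in place of 1-methylbutyl on an aromatic nitrogen and amounts to pentan-3-yl in place of 1-methylbutyl on an aromatic nitrogen.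

Among the compounds with values here, three measured steps bear on this change. Within the data shown here, the swap of pentyl for 1-methylbutyl shows a 1.5-fold higher number from compound 2 to compound 3 (0.18 log units; within the scatter) and is the closest precedent, since it also keeps the atoms and rearranges the chain. The added methyl at the chain end shows a 1.1-fold higher number from compound 1 to compound 2 (0.02 log units; within the scatter) and the added methyl on the carbon bound to the aromatic nitrogen shows a 1.6-fold higher number from compound 1 to compound 3 (0.20 log units; within the scatter) in the same range. None of them leaves the scatter. Among the measured compounds shown here, no measured compound carries pentan-3-yl, so this rests on analogy alone, and no step beyond the scatter is expected in this assay at this position. The expected step is a 1.1-fold lower number from compound 3 to compound 4 (0.06 log units; within the scatter) with no direction firmly favoured. Compound 4 is estimated at 2800 nM (expected range 1500 nM to 5500 nM).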

Compound 4, half-maximal inhibitory concentration: 2900 nM
Compound 4: the middle estimate sits 1.0-fold (0.02 log units) below what was measured; low and high end bracket the measured number.
By their numbers in this assay, from the lowest: compounds 1, 2, 4 and 3 (each within the scatter of the next).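

In this assay, moving the branch so that pentan-3-yl stands in place of 1-methylbutyl on the aromatic nitrogen gives a 1.1-fold lower number from compound 3 to compound 4 (0.04 log units; within the scatter) and so leaves these two branched isomers, with the same atoms joined differently, indistinguishable in this read-out. Against the unbranched chains, pentan-3-yl in place of pentyl gives a 1.4-fold higher number from compound 2 to compound 4 (0.14 log units; within the scatter) and pentan-3-yl in place of butyl gives a 1.5-fold higher number from compound 1 to compound 4 (0.16 log units; within the scatter) and thus, across butyl, pentyl, 1-methylbutyl and pentan-3-yl, no step on this nitrogen leaves the scatter, with no compound among these going against that flat picture. No independent evidence accompanies these numbers, so nothing can be said about what lies behind them.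

The compounds shown leave open whether a group of another kind on this nitrogen, such as benzyl, a chain ending in an amine or a chain ending in a carboxylic acid, would give a step beyond the scatter. From the compounds shown here alone, the limits of the flat range for simple chains also remain open, from a small methyl at one end to a longer chain such as octyl at the other.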